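Bromo for propyl on the five-membered sulfur ring

The source may report more compounds than this note shows. Statements on the series, on what has been measured and on what is new or still open speak of the compounds shown alone.

Measured compounds:
Compound 1 `Cc1ccsc1CN[C@@H]1C[C@H]2C[C@@H]([C@H]1C)C2(C)C`: 10000 nM
Compound 2 `CCc1csc(CN[C@@H]2C[C@H]3C[C@@H]([C@H]2C)C3(C)C)c1`: 25000 nM
Compound 3 `CCCc1csc(CN[C@@H]2C[C@H]3C[C@@H]([C@H]2C)C3(C)C)c1`: 12500 nM

In an ADME assay on MDCK cells (Canis lupus familiaris) for cytotoxicity, read by microscopy, with a stated time of 48 h (on this read-out lower numbers stand for higher toxicity in this test and higher numbers for lower toxicity in this test), compound 3 stands second highest of the three numbers; its gaps to compound 1 and to compound 2 are both within the scatter. Going by the values given here, the single measured step, a 2.0-fold lower number from compound 2 to compound 3 (0.30 log units; within the scatter), lengthens the saturated chain on the ring and is itself within the scatter. Compound 4 `C[C@H]1[C@H](NCc2cc(Br)cs2)C[C@H]2C[C@@H]1C2(C)C` differs from compound 3 as follows: bromo in place of propyl on an aromatic carbon. Among the compounds with values here, no measured step replaces a chain by bromo on this ring, so the chain step is only a loose guide; the three numbers so far sit close together, and no step beyond the scatter is expected. Compound 4 is expected near 12500 nM, with a range from 6000 nM to 25000 nM. The expected step is no change at the digits printed from compound 3 to compound 4 (within the scatter).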

Compound 4, minimum cytotoxic concentration: 6250 nM
For compound 4 the middle estimate is 2.0-fold (0.30 log units) above the measured one; measured number inside the range.
By their numbers in this assay, from the lowest: compounds 4, 1, 3 and 2 (each within the scatter of the next, the first and the last beyond it).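

In this assay, going by these compounds alone, bromo on this aromatic carbon, two ring bonds from the ring sulfur, gives the first step beyond the scatter when it replaces ethyl (a 4.0-fold lower number from compound 2 to compound 4 (0.60 log units; beyond the scatter)). In place of propyl, the change stays within the scatter (a 2.0-fold lower number from compound 3 to compound 4 (0.30 log units; within the scatter)). The swap of 3-methylthiophen-2-yl for 4-bromothiophen-2-yl also stays within it (a 1.6-fold lower number from compound 1 to compound 4 (0.20 log units; within the scatter)). Still open, from the compounds shown here alone, is how chloro, an amine or a carboxylic acid on this aromatic carbon would read. Nothing at hand accounts for these steps.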